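The source may hold more compounds than are shown below. What is called first, only, known or untested is meant among the compounds shown, and "the series" means these compounds.

Values in a functional assay on HeLa cells (Homo sapiens) for inhibition, read by CCK-8 assay, with a stated time of 72 h, tested at 2 uM; on this read-out lower numbers stand for less inhibition of growth and higher numbers for more inhibition of growth at the one concentration tested:
- compound 1 `Cc1cc(C)cc(SCc2ccc(/C=C/C(=O)Nc3ccccc3N)cc2)c1`: 11.7%
- compound 2 `CCc1ccc(SCc2ccc(/C=C/C(=O)Nc3ccccc3N)cc2)cc1`: 3.96%
- compound 3 `Nc1ccccc1NC(=O)/C=C/c1ccc(CSCCc2ccccc2)cc1`: 0.19%

Compound 3 stands at the low end of this small set, though only one of its two gaps is beyond the scatter: a number 3.8 percentage points lower from compound 2 to compound 3 (within the scatter), and a number 11.5 percentage points lower from compound 1 to compound 3 (beyond the scatter).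

The next compound, compound 4 `CC(C)(C)c1ccc(SCc2ccc(/C=C/C(=O)Nc3ccccc3N)cc2)cc1`, carries 4-(tert-butyl)phenyl in place of phenethyl on a sulfur. Within the data shown here, no measured compound carries this group, so the evidence is indirect.

The closest measured exchange is that of 4-ethylphenyl for phenethyl, seen as a number 3.8 percentage points lower from compound 2 to compound 3 (within the scatter) and here to be read in the opposite direction. Among the measured compounds shown here, the exchange involving 3,5-dimethylphenyl, a number 11.5 percentage points lower from compound 1 to compound 3 (beyond the scatter), is the only measured step beyond the scatter, and it is modest. The exchange between the two substituted phenyl groups gave a number 7.7 percentage points lower from compound 1 to compound 2 (within the scatter), so the choice of substituents on that phenyl has not yet shown a clear effect.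

A small rise is therefore expected, with no change beyond the scatter. The expected step is a number 5.8 percentage points higher from compound 3 to compound 4 (within the scatter). The estimate for compound 4 is 6%, with an expected range from 0% to 16%.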

Compound 4, percent growth inhibition at one concentration: 17.5%
Estimate against measurement, compound 4: 11.5 percentage points below; measured number above the stated range.
By their numbers in this assay, from the lowest: compounds 3, 2, 1 and 4 (each within the scatter of the next, the first and the last beyond it).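

In this assay, the exchange of 4-(tert-butyl)phenyl for phenethyl on the sulfur gives a step beyond the scatter (a number 17.3 percentage points higher from compound 3 to compound 4 (beyond the scatter)), and the substituent on the phenyl group now also shows an effect: tert-butyl in place of ethyl on an aromatic carbon gives a step beyond the scatter (a number 13.5 percentage points higher from compound 2 to compound 4 (beyond the scatter)), whereas the earlier exchange between substituted phenyl groups stayed within it. The exchange of 4-(tert-butyl)phenyl for 3,5-dimethylphenyl on the sulfur stays within the scatter (a number 5.8 percentage points higher from compound 1 to compound 4 (within the scatter)), so these two groups cannot be ordered and a phenyl group on the sulfur does not by itself set the number, as the ethyl-bearing compound 2 also shows. No measurement among the data shown gives a reason for these steps.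

From the compounds shown here alone, the effect of the substituent rests on a single pair, ethyl against tert-butyl, so it remains open whether isopropyl would fall between them. Also open, going by these compounds, are how an amine or a carboxylic acid in place of tert-butyl on that aromatic carbon would read, and whether a benzyl group on the sulfur would group with phenethyl or with the substituted phenyl groups.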